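This account rests on a few compounds, and the source may have more. Where it says the series, first, only, none or still open, it means among the compounds named here.

Measured so far in a functional assay on CHO cells for agonist activity at Alpha-1A adrenergic receptor (Homo sapiens), read by FLIPR and calcium flux; on this read-out higher numbers stand for larger maximal responses and lower numbers for smaller maximal responses:

Compound 1 `Cc1ccc2c(c1NS(C)(=O)=O)CCC2c1ncc[nH]1`: compound 1 gives 83%.
Compound 2 `Cc1oncc1-c1cccc2c1CCC2c1ncc[nH]1`: compound 2 gives 63%.
Compound 3 `CCS(=O)(=O)Nc1cccc(Cc2c[nH]cn2)c1`: compound 3 gives 96%.

Compound 2 stands lowest of the three numbers. Nearest to it is compound 1, with a number higher by more than the usual scatter; furthest is compound 3, whose number lies higher still and also beyond the scatter.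

Compound 4 `c1cc(-c2ncco2)c2c(c1)C(c1ncc[nH]1)CC2` differs from compound 2 in one place:

1,3-oxazol-2-yl in place of 5-methyl-1,2-oxazol-4-yl on an aromatic carbon

For the measured compounds named here, no pair of measured compounds differs in this way, so the size of such a step is not known from the measured set. The expectation in this assay is a step of no size beyond the scatter, with some allowance toward the higher numbers shown by compound 1 and compound 3. For compound 4 the estimated maximal response in this assay is 67%, with a range from 48% to 86%. This estimate corresponds to an expected step of a number 4 percentage points higher from compound 2 to compound 4 (within the scatter).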

Compound 4, largest response reached (Emax), in percent of the reference or control that the assay uses: 63%
Estimate against measurement, compound 4: 4 percentage points above; low and high end bracket the measured number.
By their numbers in this assay, from the lowest: compounds 2 and 4 (each within the scatter of the next); then compound 1; then compound 3.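

In this assay, 1,3-oxazol-2-yl in place of 5-methyl-1,2-oxazol-4-yl on an aromatic carbon gives no change at the digits printed from compound 2 to compound 4 (within the scatter). For the compounds shown here, this is the first step read at this position: for this pair, exchanging one five-membered aromatic ring with 2 hetero atoms for another, with a different attachment and without the methyl, leaves compound 4 at 63%, so the maximal response does not separate the two groups. No measurement available here accounts for this result.

Still open, from the compounds shown here alone, is whether the response at this position holds only among such five-membered aromatic rings, or also with a primary amine, a carboxylic acid or a longer alkyl chain on the same aromatic carbon. Also open, going by these compounds, is what a methyl group added to the 1,3-oxazol-2-yl ring would do.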